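Aryl ether series: methyl to methoxy on the terminal ring

The source may hold more compounds than are shown below. What is called first, only, known or untested is meant among the compounds shown, and "the series" means these compounds.

Working notes on the shared core. Compound 1 `CC(Oc1ccccc1)C(=O)Nc1ccc(OCC(=O)O)c(F)c1` carries a phenoxy group on a branched linker; in a functional assay on CHO cells for agonist activity at Free fatty acid receptor 1 (Homo sapiens), read by FLIPR (a lower number here means that less compound is needed, a higher number that more compound is needed for the effect), compound 1 gives 135 nM. Compound 2 `Cc1cccc(OCC(=O)Nc2ccc(OCC(=O)O)c(F)c2)c1` carries a 3-methylphenyl ether on the amide side; in this assay compound 2 gives 108 nM, the lower of the two numbers obtained so far, though its gap to compound 1 lies within the scatter, so no order between the two is read. Compound 3 `CC(C)c1ccc(OCC(=O)Nc2ccc(OCC(=O)O)c(F)c2)cc1`, with an isopropyl-bearing phenyl ether, stands in this assay as "not determined" (no result reported), so no number is available for it. Compound 4 `COc1cccc(OCC(=O)Nc2ccc(OCC(=O)O)c(F)c2)c1` is the next entry and has not yet been measured. Its difference from compound 2: methoxy in place of methyl on an aromatic carbon. Within the data shown here, no step between measured compounds is available to calibrate this change, and the methyl to methoxy pair occurs nowhere else among compounds 1 to 3. The expectation is therefore a step of a 1.1-fold higher number from compound 2 to compound 4 (0.05 log units; within the scatter), that is, nothing beyond the scatter. Compound 4 is thus estimated at 120 nM in this assay, with a range from 50 nM to 300 nM.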

Compound 4, half-maximal effective concentration: 148 nM
Estimate against measurement, compound 4: 1.2-fold (0.09 log units) below; the range from low to high includes it.
By their numbers in this assay, from the lowest: compounds 2, 1 and 4 (each within the scatter of the next).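

The change of 3-methylphenyl to 3-methoxyphenyl gives the series its first step at this position: in this assay, methoxy in place of methyl, meta to a large group, gives a 1.4-fold higher number from compound 2 to compound 4 (0.14 log units; within the scatter). With that step inside the scatter, no order can be read between compound 2 and compound 4, so the extra oxygen and its added hydrogen-bond acceptor bring no readable shift at this position. No measurement on hand bears on why the two compounds stand so close.

From the compounds shown here alone, what remains open is whether a group of another kind on this aromatic carbon, such as an amine, a carboxylic acid or a longer chain such as butoxy, would move the number beyond the scatter. Also open, going by these compounds, is whether methoxy in place of methyl gives a similar step on another carbon of this ring.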